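Trading a Morpholine Side Chain for a Short Methoxy Ether

The compounds below may be only part of what the source reports. "The series", "measured", "known", "first", "only" and "open" are said of these compounds alone.

Of the compounds shown here, two sharing one core have been measured in a physicochemical assay for lipophilicity, at pH 7.4; on this read-out lower numbers stand for lower lipophilicity and higher numbers for higher lipophilicity. Compound 1 `CNC(=O)c1cc(C(=O)NCCCC2CNCCO2)cn(Cc2ccccc2)c1=O` gives 1.4 in this assay. Compound 2 `CNC(=O)c1cc(C(=O)NC2CC2)cn(Cc2cccc(C#N)c2)c1=O` gives 2.6 in this assay. Of these two numbers, compound 1 stands lowest, and compound 2 lies above it by a gap that exceeds the usual scatter. Compound 3 `CNC(=O)c1cc(C(=O)NCCOC)cn(Cc2ccccc2)c1=O` has not yet been measured; it differs from compound 1 in one place: methoxy in place of (morpholin-2-yl)methyl on a saturated chain carbon, two bonds along the chain from an amide-type nitrogen. Among the compounds with values here, no measured pair shows this kind of change, so its effect must be judged from the structures alone. Given that compound 1 sits at 1.4 in this assay, a moderate upward step is expected for compound 3, with a number 0.70 log units higher from compound 1 to compound 3 (beyond the scatter) as the estimated shift. Compound 3 is therefore expected to reach about 2.1 in this assay, plausibly between 1.6 and 2.6.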

Compound 3, distribution coefficient: 2.7
For compound 3 the middle estimate is 0.60 log units below the measured one; measured number above the stated range.
By their numbers in this assay, from the lowest: compound 1; then compounds 2 and 3 (each within the scatter of the next).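

Replacing 3-(morpholin-2-yl)propyl with 2-methoxyethyl gives a number 1.30 log units higher from compound 1 to compound 3 (beyond the scatter) in this assay while the rest of the molecule stays the same. This shows that a change at this one place, on a saturated chain carbon two bonds along the chain from an amide-type nitrogen, can produce a large step on its own, which compounds 1 and 2 could not show, since they differ in more than one place. No measurement available here explains why the number moves this far.

The change removes a ring, a hydrogen-bond donor and part of the chain all at once, so the compounds shown cannot say which of these matters. A longer chain ending in methoxy, or an amine or a carboxylic acid in place of methoxy, would be the next groups to compare at this place.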